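Halogen swap on the aryl sulfone of compound 1

The compounds below may be only part of what the source reports. "The series", "measured", "known", "first", "only" and "open" are said of these compounds alone.

Measured in an assay on isolated protein for displacement of a labelled ligand from metabotropic glutamate receptor 5 (Homo sapiens), with a stated time of 60 min, tested at 1 uM; a lower number here means less inhibition, a higher number more inhibition at the concentration tested (going by the name of the read-out):
compound 1 `Cc1ccc(S(=O)(=O)c2cnc3ccc(Cl)cc3c2N2CCC(C)CC2)cc1F` — 68%
compound 2 `CCN1CCN(c2c(S(=O)(=O)c3ccccc3)cnc3ccccc23)CC1` — 1.7%
compound 3 `COc1ccc2ncc(S(=O)(=O)c3ccc(C)c(F)c3)c(N3CCC(C)CC3)c2c1` — 73%

Compound 1 stands second of the three numbers in this assay. Its nearest neighbour is compound 3, reached by a number 5 percentage points higher from compound 1 to compound 3 (within the scatter), a step within the scatter. Going by the values given here, compound 2, which differs from compound 1 in several places at once, lies far lower; no single step joins the two, so only the two values themselves can be compared.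

Compound 4 `Cc1ccc(S(=O)(=O)c2cnc3ccc(Cl)cc3c2N2CCC(C)CC2)cc1Cl` is not yet measured. It differs from compound 1 by chloro in place of fluoro on an aromatic carbon, on an aromatic carbon ortho to a methyl group and meta to a large group. Among the compounds with values here, no measured step touches this position: the one step available, from compound 1 to compound 3, changes a different ring and stays within the scatter. With nothing bearing directly on the change, the expected step of no change at the digits printed from compound 1 to compound 4 (within the scatter) is one not beyond the scatter, in no particular direction. Compound 4 is therefore estimated at 68% in this assay, with a range from 50% to 84%.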

Compound 4, a percentage reported as inhibition, at one concentration (the size of the read-out at that concentration, not a potency): 81%
The estimate for compound 4 lay 13 percentage points below the measured number, and the stated range covers the measured number.
By their numbers in this assay, from the lowest: compound 2; then compounds 1, 3 and 4 (each within the scatter of the next, the first and the last beyond it).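

In this assay, going by these compounds alone, the change from 3-fluoro-4-methylphenyl to 3-chloro-4-methylphenyl gives a number 13 percentage points higher from compound 1 to compound 4 (beyond the scatter) and is the first reading at this position on the aryl sulfone. Within the data shown here, the halogen here therefore moves the number by more than the usual scatter, a modest but real response, whereas the one earlier single-place step, a number 5 percentage points higher from compound 1 to compound 3 (within the scatter) and on the other ring, did not leave the scatter. Nothing measured here explains the difference between chloro and fluoro at this position.

Still open, as far as these compounds go, is how a bromo, a trifluoromethyl or a plain hydrogen would read at this same position. From the compounds shown here alone, it is also open whether the chloro step holds when methoxy replaces the chloro on the shared core.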